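The source may hold more compounds than are shown below. What is called first, only, known or untested is meant among the compounds shown, and "the series" means these compounds.

The series rests on one core, carried in `COc1cccc(Cn2cc(-c3ccc([N+](=O)[O-])cc3)nn2)c1` as compound 1, which in a functional assay on B16 cells (Mus musculus) for cytotoxicity, read by MTT assay, with a stated time of 48 h (on this read-out lower numbers stand for stronger inhibition and higher numbers for weaker inhibition), gives 19100 nM. Compound 2, `CCOC(=O)Cn1cc(-c2ccc3ccccc3c2)nn1`, reports only a limit in this assay, > 100000 nM. Compound 3, `COc1ccc(-c2cn(C[C@H]3COC(C)(C)O3)nn2)cc1`, likewise returns a limit in this assay, > 100000 nM. For the measured compounds named here, compound 2 thus stands at the limit of > 100000 nM in this assay, at which 2 of the 3 values shown sit, and since no step between two measured compounds is available, the size of the change that follows can only be expected, not read off. The compound still to be measured is compound 4, `c1ccc(Cn2cc(-c3ccc4ccccc4c3)nn2)cc1`. Set against compound 2, the change is phenyl in place of ethoxycarbonyl on a saturated chain carbon bound to an aromatic nitrogen. Going by the values given here, with compound 1 as the only member carrying a number, the step is expected to move toward stronger inhibition, yet compound 4 is expected to remain weak, because compound 1 itself gives only 19100 nM. Compound 4 is expected near 40000 nM, within 10000 nM to 150000 nM. The step this implies is estimated as an at least 2.5-fold lower number from compound 2 to compound 4 (0.39 log units; beyond the scatter).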

Compound 4, half-maximal inhibitory concentration: 3890 nM
Compound 4: middle estimate off by 10-fold (1.01 log units), on the high side, outside the stated range (below it).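

In this assay, for the compounds shown here, phenyl in place of ethoxycarbonyl on a saturated chain carbon bound to an aromatic nitrogen gives an at least 25-fold lower number from compound 2 to compound 4 (1.41 log units; beyond the scatter), the first step that can be sized. With the rest of the two molecules unchanged, this one position is enough to separate a compound with a measured number from one that sits at the assay's limit. Going by these compounds, the step is only a lower bound, and its true size remains unknown, since the value of compound 2 is a limit: the limit of > 100000 nM in this assay, at which 2 of the 4 values shown sit.

The compounds shown leave open whether the lower number comes from the phenyl ring itself or from the loss of ethoxycarbonyl, which a carboxylic acid or an amine at this position could help separate. They also do not show whether a phenethyl group would keep the lower number.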